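Compound 2 to compound 3: a swap at the carbonyl carbon

This account rests on a few compounds, and the source may have more. Where it says the series, first, only, none or still open, it means among the compounds named here.

Compound 1 `COc1ccc(NC(=O)N[C@@H]2C3CCN(CC3)[C@@H]2Cc2cccnc2)c(OC)c1` gives only a limit of the assay in an assay on a protein complex for binding affinity to Neuronal acetylcholine receptor; alpha4/beta2 (Homo sapiens) (a lower number here means a stronger inhibitor, a higher number a weaker inhibitor), > 10000 nM. Compound 2 `CSc1ccc(NC(=O)N[C@@H]2C3CCN(CC3)[C@@H]2Cc2cccnc2)cc1` likewise gives only a limit, > 10000 nM. Among the compounds with values here, compound 2 therefore stands at the limit, where both values so far sit (the limit of > 10000 nM in this assay, at which 2 of the 2 values shown sit), so no step between measured compounds can be sized. Compound 3 `C/C(=C\c1ccccc1)C(=O)N[C@@H]1C2CCN(CC2)[C@@H]1Cc1cccnc1` carries 1-methyl-2-phenylethenyl in place of (4-(methylsulfanyl)phenyl)amino on a carbonyl carbon. With nothing measured to point a direction, no change beyond the scatter is expected, and the expected step is a number no higher from compound 2 to compound 3 (the limit leaves the size open). Compound 3 is estimated at 10000 nM, within 3000 nM to 30000 nM, most probably again reported only as a limit.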

Compound 3, inhibition constant: > 10000 nM
Compound 3: a limit, no number; the forecaster's own chance of this, stated with the estimate: 70%; the middle value sits exactly at the limit.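

In this assay compound 3 gives only a limit of the assay, > 10000 nM. Compound 2 also stands at a limit, so the step to compound 3 cannot be read. The compounds shown leave open what affinity any of them actually has.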